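The source may hold more compounds than are shown below. What is called first, only, known or untested is meant among the compounds shown, and "the series" means these compounds.

In a functional assay for activation of Alpha-1B adrenergic receptor (Homo sapiens), read by calcium flux (a higher number here means that more compound is needed for the effect, a lower number that less compound is needed), compound 1 `c1c[nH]c(-c2ccccc2OCC2=NCCN2)c1` gives 1 nM, compound 2 `c1ccc(-c2ccsc2)c(OCC2=NCCN2)c1` gives 15.9 nM, and compound 3 `c1ccc(-c2cc[nH]n2)c(OCC2=NCCN2)c1` gives 79.4 nM, which is the highest of the three numbers. The ring attached to the shared core changes from one compound to the next: the step of a 16-fold higher number from compound 1 to compound 2 (1.20 log units; beyond the scatter) and the step of a 79-fold higher number from compound 1 to compound 3 (1.90 log units; beyond the scatter) were both large, while the step of a 5.0-fold higher number from compound 2 to compound 3 (0.70 log units; beyond the scatter) was modest. Compound 4 `c1ccc(-c2ncc[nH]2)c(OCC2=NCCN2)c1` is the next member of this series, and the change from compound 3 is 1H-imidazol-2-yl in place of 1H-pyrazol-3-yl on an aromatic carbon. Since every ring swap so far has moved this assay beyond the scatter, a shift is expected, and for compound 4 an estimated value of 30 nM with a range from 6 nM to 150 nM corresponds to an expected step of a 2.6-fold lower number from compound 3 to compound 4 (0.42 log units; beyond the scatter).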

Compound 4, half-maximal effective concentration: < 100000 nM
Compound 4 ended at the assay's limit (the forecaster's own chance of this, stated with the estimate: 3%); the middle value lies beyond the limit too.
By their numbers in this assay, from the lowest: compound 1; then compound 2; then compound 3.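

In this assay compound 4 gives < 100000 nM, which is a limit and not a number. Its steps from compound 1, compound 2 and compound 3 cannot be read. From the compounds shown here alone, how 1H-imidazol-2-yl truly compares with the other three rings stays open.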